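The source may report more compounds than this note shows. Statements on the series, on what has been measured and on what is new or still open speak of the compounds shown alone.

Working notes on the thiazolidinone series. Compound 1 `Cc1nc(-c2ccc(Cl)cc2)sc1C1SCC(=O)N1c1ccc(F)c(Cl)c1` and compound 2 `Cc1nc(-c2ccc(Cl)cc2)sc1C1SCC(=O)N1c1ccc(F)cc1` share one core and differ only on the aromatic ring that sits on the amide nitrogen. In a functional assay on the whole organism (strain Wistar albino) for inhibition, with Rattus norvegicus as the target, read by paw edema, with a stated time of 1 h, at a dose of 40 mg/kg by the oral route (on this read-out lower numbers stand for less inhibition and higher numbers for more inhibition at the one dose given (going by the name of the read-out)), compound 1 gives 53.4%, and in this assay compound 2 gives 63.4%. Among the compounds with values here, the step of a number 10 percentage points higher from compound 1 to compound 2 (within the scatter) is the only measured step so far, and it stays inside the scatter of the read-out. Compound 2 therefore stands together with compound 1: the two values cannot be told apart on the numbers available, and neither compound can be said to give the higher number in this assay.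

Compound 3 `Cc1nc(-c2ccc(Cl)cc2)sc1C1SCC(=O)N1c1ccc(Cl)cc1` is the next member. Relative to compound 2 the change is chloro in place of fluoro on an aromatic carbon. Within the data shown here, the one measured step, from chloro to hydrogen on an aromatic carbon of the same six-membered aromatic ring of carbon only, was within the scatter; it is the only step that bears on the present change, and it argues for no movement beyond the scatter in this assay. The step of a number 3.4 percentage points lower from compound 2 to compound 3 (within the scatter) is expected to be small. For compound 3 the value in this assay is estimated at 60%, with a range from 45% to 75%.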

Compound 3, a percentage reported as inhibition, in the whole organism at one dose (the size of the read-out at that dose, not a potency): 69.3%
Estimate against measurement, compound 3: 9.3 percentage points below; the range from low to high includes it.
By their numbers in this assay, from the lowest: compounds 1, 2 and 3 (each within the scatter of the next, the first and the last beyond it).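

In this assay, chloro in place of fluoro on an aromatic carbon, para to a large group, gives a number 5.9 percentage points higher from compound 2 to compound 3 (within the scatter), so this exchange of one halogen for the other at this position cannot be resolved from the scatter, and compound 2 and compound 3 stand together. Within the data shown here, the comparison of 4-chlorophenyl with 3-chloro-4-fluorophenyl on the amide-type nitrogen in a ring gives a number 15.9 percentage points higher from compound 1 to compound 3 (beyond the scatter), a modest step and the first to lie beyond the scatter, although compound 2 remains within the scatter of both compound 1 and compound 3, so no single compound stands clear of the other two. No available evidence bears on what underlies this step.

The compounds shown leave open whether a group other than a halogen at the same place on the ring, such as a methoxy group, a dimethylamino group or a carboxylic acid, would stay within the scatter of compound 2 and compound 3. They also leave open how an unsubstituted phenyl on the amide-type nitrogen would compare with these three halogen-bearing rings.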